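The compounds below may be only part of what the source reports. "The series", "measured", "known", "first", "only" and "open" are said of these compounds alone.

Compound 1 `O=C1/C(=C/c2cccnc2)CN(S(=O)(=O)c2ccc(F)cc2)C/C1=C\c1ccccc1F` and compound 2 `N#Cc1ccc(S(=O)(=O)N2C/C(=C\c3cccnc3)C(=O)/C(=C/c3ccccc3F)C2)cc1` share the same core and differ only in one group on the aromatic ring that carries the sulfonyl. In an ADME assay on L02 cells (Homo sapiens) for cytotoxicity, read by MTT assay, with a stated time of 24 h (on this read-out higher numbers stand for weaker inhibition and lower numbers for stronger inhibition), compound 1 gives 15600 nM. In this assay compound 2 gives > 20000 nM, which is a limit of the assay and not a number. The step of an at least 1.2-fold higher number from compound 1 to compound 2 (0.10 log units; that floor lies within the scatter) therefore rests on (the limit of > 20000 nM in this assay, at which 1 of the 2 values shown sits). Compound 2 thus stands at that limit, the weaker end of the two values shown, and no firm number is known for it.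

Compound 3 `N#Cc1ccc(S(=O)(=O)N2C/C(=C\c3ccncc3)C(=O)/C(=C/c3ccccc3F)C2)cc1` has not yet been measured. It differs from compound 2 by pyridin-4-yl in place of pyridin-3-yl on a double-bonded chain carbon bound to a double-bonded ring carbon. Among the measured compounds shown here, none of the measured steps touches this part of the molecule, so the single measured step, an at least 1.2-fold higher number from compound 1 to compound 2 (0.10 log units; that floor lies within the scatter), does not speak directly to the change; it only shows where compound 2 sits. With no guidance either way, no step beyond the scatter is expected in this assay, and the expected step that the limit leaves unreadable from compound 2 to compound 3 is small. Compound 3 is therefore estimated to give about 25000 nM, within 12000 nM to 60000 nM, and quite possibly only a limit again.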

Compound 3, half-maximal inhibitory concentration: > 20000 nM
Compound 3: only a limit was reported (the forecaster's own chance of this, stated with the estimate: 70%); the middle value lies beyond the limit too.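

No step can be read from compound 2 to compound 3, since this assay reports each of them only as a limit and not as a number: the limit of > 20000 nM in this assay, at which 2 of the 3 values shown sit.

The compounds shown leave open what firm values compound 2 and compound 3 have, and so whether pyridin-4-yl in place of pyridin-3-yl makes any difference.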